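Adding a Methyl at Two Different Chain Positions

This account rests on a few compounds, and the source may have more. Where it says the series, first, only, none or still open, it means among the compounds named here.

Compound 1 `CC[C@H](Nc1cncc(-c2ccc(O)c(OC)c2)n1)c1ccccc1`: 10000 nM
Compound 2 `CCC[C@H](Nc1cncc(-c2ccc(O)c(OC)c2)n1)c1ccccc1`: 160 nM
Compound 3 `CCCC(Nc1cncc(-c2ccc(O)c(OCC)c2)n1)c1cccnc1`: 1000 nM

These values come from a functional assay on PC-3 cells (Homo sapiens) for cytotoxicity, read by MTT assay, with a stated time of 72 h; a higher number here means a weaker inhibitor, a lower number a stronger inhibitor. Going from compound 1 to compound 2 means methyl in place of hydrogen on a saturated chain carbon, three bonds along the chain from an aromatic carbon and a nitrogen on an aromatic ring and brings a 63-fold lower number from compound 1 to compound 2 (1.80 log units; beyond the scatter). Compound 3 has a different core; the difference between the core of compound 1 and the core of compound 3 is not broken down here. Compound 4 `CCCC(Nc1cncc(-c2ccc(O)c(OC(C)C)c2)n1)c1cccnc1` has not yet been measured. It differs from compound 3 by methyl in place of hydrogen on a saturated chain carbon bound to an oxygen on an aromatic ring and a saturated chain carbon. Among the compounds with values here, this is the same kind of change as the one between compound 1 and compound 2, a methyl entering for a hydrogen, but not the same: the earlier place was a saturated chain carbon three bonds along the chain from an aromatic carbon and a nitrogen on an aromatic ring, whereas here the place is a saturated chain carbon bound to an oxygen on an aromatic ring and a saturated chain carbon. Within the data shown here, the earlier step was large, but no measured pair shows a methyl added at the place changed in compound 4, so a smaller step is expected. In this assay the expected step is a 1.4-fold lower number from compound 3 to compound 4 (0.15 log units; within the scatter). Compound 4 is estimated at 700 nM, with a likely range from 200 nM to 2500 nM.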

Compound 4, half-maximal inhibitory concentration: 10000 nM
Compound 4: the middle estimate sits 14-fold (1.15 log units) below what was measured; the whole stated range lies below it.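

In this assay, replacing ethoxy with isopropoxy gives a 10-fold higher number from compound 3 to compound 4 (1.00 log units; beyond the scatter), so this methyl moves the number the opposite way from the earlier one: the same change on two cores in this assay, a 63-fold lower number (1.80 log units; beyond the scatter) from compound 1 to compound 2 and a 10-fold higher number (1.00 log units; beyond the scatter) from compound 3 to compound 4, 630-fold (2.80 log units) apart, beyond the scatter of two such steps For these two pairs, then, knowing that a methyl enters for a hydrogen does not predict even the direction of the result, let alone its size. The two pairs differ both in the core and in the place of the methyl, however, so they do not show whether the core, the place or both set the outcome, and two pairs make no general rule for the series.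

The compounds shown leave open whether replacing ethoxy with isopropoxy would give a similar step on the core of compound 2, which would separate the core from the place. They also leave open how a longer chain on that oxygen, such as butoxy, would read in this assay.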